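Trading tert-butyl for methylamino on an aromatic carbon

A few compounds are considered here, and "the series" means these few. Any claim that something is new, unique, unknown or untested is made for them only; others in the source may bear on it.

Of the compounds shown here, three have been measured in a functional assay on the whole organism for inhibition, with Rattus norvegicus as the target, at a dose of 1 mg/kg by the oral route; a higher number here means a stronger effect of the compound at the dose given, a lower number a weaker effect. Compound 1 `COc1cc(C(=O)Nc2nn[nH]n2)nc(-c2ccccc2OC)c1` gives 41%. Compound 2 `CCCCc1ccc(-c2cc(OC)cc(C(=O)Nc3nn[nH]n3)n2)cc1` gives 29%, and compound 3 `COc1cc(C(=O)Nc2nn[nH]n2)nc(-c2ccc(C(C)(C)C)cc2)c1` gives 29%. For the measured compounds named here, the one step that joins two measured compounds, no change at the digits printed from compound 2 to compound 3 (within the scatter), shows tert-butyl in place of butyl on an aromatic carbon. Compound 3 therefore sits level with compound 2 and, together with it, at the lowest of the three numbers, while compound 1 stands a number above it that lies beyond the scatter.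

Compound 4 `CNc1ccc(-c2cc(OC)cc(C(=O)Nc3nn[nH]n3)n2)cc1` is the next compound, and it differs from compound 3 as follows: methylamino in place of tert-butyl on an aromatic carbon. Going by the values given here, no measured step exchanges tert-butyl for methylamino, so nothing measured bears directly on this change; the only step available, from butyl to tert-butyl, lay within the scatter. The expectation for compound 4 in this assay is therefore a step of about a number 4 percentage points higher from compound 3 to compound 4 (within the scatter), which is within the scatter, with wide uncertainty. Compound 4 is estimated at 33%, in a range from 15% to 55%.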

Compound 4, a percentage reported as inhibition, in the whole organism at one dose (the size of the read-out at that dose, not a potency): 35%
Beside the measured number, compound 4's estimate is 2 percentage points below it; measured number inside the range.
By their numbers in this assay, from the lowest: compounds 2, 3, 4 and 1 (each within the scatter of the next, the first and the last beyond it).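

In this assay, methylamino at this position, on an aromatic carbon para to a large group, gives a number 6 percentage points higher from compound 3 to compound 4 (within the scatter) and a number 6 percentage points higher from compound 2 to compound 4 (within the scatter), so replacing either all-carbon group with one that has one hydrogen-bond donor and one hydrogen-bond acceptor does not separate the read-outs. The larger exchange of the whole aromatic substituent gives a number 6 percentage points lower from compound 1 to compound 4 (within the scatter), which places compound 4 within the scatter of all three earlier compounds, even though compound 1 and compound 3 lie beyond it from each other. Nothing at hand accounts for these results.

From the compounds shown here alone, whether a carboxylic acid, a dimethylamino group or a longer chain at this position would move the number beyond the scatter remains open. With a single oral dose, the compounds also leave open how these read-outs would compare at other doses.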